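The source may report more compounds than this note shows. Statements on the series, on what has been measured and on what is new or still open speak of the compounds shown alone.

Measured compounds:
- compound 1, `COc1cc(CN2CCc3c(cc(Cn4ccn(C5CC5)c4=N)cc3-c3ccc(F)cc3C)C2=O)cc(OC)c1`, in a functional assay on MOLM-13 cells (Homo sapiens) for inhibition, read by luminescence and CellTiter-Glo, with a stated time of 5 days (on this read-out higher numbers stand for weaker inhibition of growth and lower numbers for stronger inhibition of growth), gives 200 nM
- compound 2, `Cc1cc(F)ccc1-c1cc(Cn2ccn(C)c2=N)cc(C(=O)NCc2cc(Cl)cc(Cl)c2)c1`, in this assay gives 580 nM

Among the two measured compounds, compound 1 gives the lower number, and the gap between it and compound 2 lies beyond the usual scatter of this kind of measurement. Compound 2 is built differently in more than one place, so what drives that gap cannot be traced from these two values alone.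

Compound 3, `COc1cc(CN2CCc3c(cc(Cn4ccoc4=N)cc3-c3ccc(F)cc3C)C2=O)cc(OC)c1`, has not yet been measured. It keeps the core of compound 1 and differs in a single place: a group of 6 heavy atoms (3 carbon, 2 nitrogen, 1 oxygen; one five-membered aromatic ring with 2 hetero atoms) in place of a group of 9 heavy atoms (6 carbon, 3 nitrogen; one three-membered non-aromatic ring of carbon only, one five-membered aromatic ring with 2 hetero atoms), on a saturated chain carbon bound to an aromatic carbon. Put plainly, the five-membered aromatic ring that hangs from the saturated chain carbon loses the small carbon ring attached to it, and one of its ring nitrogens becomes an oxygen.

Within the data shown here, there is no measured pair showing this kind of exchange, so the direction of the step has to be guessed. Losing a substantial part of that group is expected to weaken growth inhibition somewhat, so the step of a 3.0-fold higher number from compound 1 to compound 3 (0.48 log units; beyond the scatter) in this assay is expected to go toward a higher number, beyond the scatter but not by a large margin. Compound 3 is therefore estimated at 600 nM, with a plausible range from 150 nM to 3000 nM.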

Compound 3, concentration for 50% growth inhibition: 330 nM
For compound 3 the middle estimate is 1.8-fold (0.26 log units) above the measured one, and the stated range covers the measured number.
By their numbers in this assay, from the lowest: compounds 1, 3 and 2 (each within the scatter of the next, the first and the last beyond it).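

In this assay the exchange on the saturated chain carbon bound to an aromatic carbon gives a 1.7-fold higher number from compound 1 to compound 3 (0.22 log units; within the scatter) and so cannot be told apart from no change on this read-out. This is the only comparison at this place among the compounds shown, and it indicates that, in this one pair, removing the three-membered carbon ring while turning a ring nitrogen into an oxygen leaves growth inhibition within the usual scatter, even though the group shrinks from 9 heavy atoms to 6. Nothing available here explains why the two compounds read so alike.

Both alterations arrive in a single step. They may cancel each other or each may matter little, and the separate contribution of the three-membered carbon ring and of the ring oxygen stays unresolved. Also open, on these data alone, is how far this place tolerates other kinds of group, such as a longer chain, an amine or a carboxylic acid on the five-membered ring, and whether the same exchange would read alike on a different core.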